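The source may report more compounds than this note shows. Statements on the series, on what has been measured and on what is new or still open speak of the compounds shown alone.

Measured so far:
Compound 1, `C=C1C(=O)[C@]23C[C@@]1(O)CC[C@H]2c1ccc(O)c(C)c1[C@@H]3Cn1cc(-c2ccc(F)cc2)nn1`: 1700 nM
Compound 2, `C=C1C(=O)[C@]23C[C@@]1(O)CC[C@H]2c1ccc(O)c(C)c1[C@@H]3Cn1cc(-c2ccc(C(F)(F)F)cc2)nn1`: 1840 nM
Compound 3, `Cc1ccc(S(=O)(=O)Oc2ccc3c(c2C)[C@H](Cn2cc(-c4ccc(C(F)(F)F)cc4)nn2)[C@@]24CC(=O)[C@@](C)(CC[C@@H]32)C4)cc1`: > 20000 nM

In a functional assay on MCF7 cells (Homo sapiens) for cytotoxicity, read by MTT assay, with a stated time of 4 days (on this read-out lower numbers stand for stronger inhibition and higher numbers for weaker inhibition), compound 2 gives 1840 nM. Compound 1 differs from compound 2 by fluoro in place of trifluoromethyl on an aromatic carbon, and this change made a 1.1-fold lower number from compound 2 to compound 1 (0.03 log units; within the scatter). For compound 3 the result in this assay is only a limit, > 20000 nM, which is the limit of > 20000 nM in this assay, at which 1 of the 3 values shown sits. The difference between the core of compound 3 and the core of compound 2 is not broken down here. Compound 4, `Cc1ccc(S(=O)(=O)Oc2ccc3c(c2C)[C@H](Cn2cc(-c4ccc(F)cc4)nn2)[C@@]24CC(=O)[C@@](C)(CC[C@@H]32)C4)cc1`, is not yet measured; it differs from compound 3 by fluoro in place of trifluoromethyl on an aromatic carbon, the same change as from compound 2 to compound 1. Compound 4 is therefore expected to give a number close to that of compound 3. Because a 1.1-fold lower number from compound 2 to compound 1 (0.03 log units; within the scatter) was within the scatter, the estimated step for compound 4 is a step that the limit leaves unreadable from compound 3 to compound 4, with a fair chance that this assay again reports only a limit. The estimate for compound 4 is 22000 nM, between 8000 nM and 60000 nM.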

Compound 4, half-maximal inhibitory concentration: > 20000 nM
Compound 4 gave a limit, no number (the forecaster's own chance of this, stated with the estimate: 75%); the middle value is on the limit's open side.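

In this assay, within the data shown here, compound 3 and compound 4 each give only a limit, and no step between them can be read: the limit of > 20000 nM in this assay, at which 2 of the 4 values shown sit. The compounds shown leave open whether fluoro in place of trifluoromethyl shifts the result at all on the core of compound 3.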